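The compounds below may be only part of what the source reports. "The series", "measured", "known", "first", "only" and "open" are said of these compounds alone.

In a functional assay on HepG2 cells (Homo sapiens) for cytotoxicity, read by MTT assay, with a stated time of 24 h (on this read-out lower numbers stand for stronger inhibition and higher numbers for weaker inhibition), compound 3 `O=C1/C(=C/c2ccncc2)CN(S(=O)(=O)c2ccc([N+](=O)[O-])cc2)C/C1=C\c1ccccc1C(F)(F)F` gives 13400 nM. Compound 1 `O=C1/C(=C/c2ccncc2)CN(S(=O)(=O)c2ccc([N+](=O)[O-])cc2)C/C1=C\c1ccccc1F` gives 11300 nM, and compound 2 `O=C1/C(=C/c2ccncc2)CNC/C1=C\c1ccccc1C(F)(F)F` gives 6130 nM. Compound 3 therefore sits level with compound 1 within the scatter, and its number is higher than that of compound 2.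

Compound 4 `CC(=O)Nc1ccc(S(=O)(=O)N2C/C(=C\c3ccncc3)C(=O)/C(=C/c3ccccc3C(F)(F)F)C2)cc1` has not yet been measured. It carries acetamido in place of nitro on an aromatic carbon, para to a large group: acetamido in place of nitro on an aromatic carbon. Within the data shown here, no measured step makes this exchange, so the evidence is indirect. Trifluoromethyl in place of fluoro on an aromatic carbon gave a 1.2-fold higher number from compound 1 to compound 3 (0.07 log units; within the scatter). Putting (4-nitrophenyl)sulfonyl in place of hydrogen on an amine nitrogen in a ring gave a 2.2-fold higher number from compound 2 to compound 3 (0.34 log units; beyond the scatter), which is a modest step for adding a whole group.

On these data alone, both steps are small, so no change beyond the scatter is expected in this assay, although the nitro group itself remains untested. The expected step is a 1.1-fold lower number from compound 3 to compound 4 (0.05 log units; within the scatter). Compound 4 is estimated at 12000 nM, with an expected range from 5500 nM to 26000 nM.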

Compound 4, half-maximal inhibitory concentration: 4840 nM
Compound 4: the middle estimate sits 2.5-fold (0.39 log units) above what was measured, and the stated range ends above it.
By their numbers in this assay, from the lowest: compounds 4, 2, 1 and 3 (each within the scatter of the next, the first and the last beyond it).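

In this assay, the change from 4-nitrophenyl to 4-acetamidophenyl gives a 2.8-fold lower number from compound 3 to compound 4 (0.44 log units; beyond the scatter). The earlier steps shown here showed only how the number responded to changing fluoro to trifluoromethyl and to adding the whole (4-nitrophenyl)sulfonyl group; this step shows that the group carried on the aromatic carbon para to a large group matters in its own right. Acetamido brings one hydrogen-bond donor where nitro has none, but no measurement here separates that difference from the others between the two groups, and nothing available explains the step.

The compounds shown cover only nitro and acetamido at this position, so the effect of an amine, a carboxylic acid or a longer amide chain there stays open. Also open, on these data alone, is whether the same exchange would give a similar step with fluoro in place of trifluoromethyl.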